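The source may hold more compounds than are shown below. What is called first, only, known or untested is meant among the compounds shown, and "the series" means these compounds.

Measured compounds:
- compound 1, `CCOc1cccc(/C=N/c2c(C)n(C)n(-c3ccccc3)c2=O)c1` — 933000000 nM
- compound 2, `Cc1c(/N=C/c2ccccc2Cl)c(=O)n(-c2ccccc2)n1C` — 851000000 nM
- compound 3, `COc1cccc(/C=N/c2c(C)n(C)n(-c3ccccc3)c2=O)c1` — 933000000 nM

In a functional assay on HCT-116 cells (Homo sapiens) for cytotoxicity, read by MTT assay, with a stated time of 72 h (a lower number here means a stronger inhibitor, a higher number a weaker inhibitor), compound 3 gives 933000000 nM, a number level with compound 1 and within the scatter of compound 2, so the three measured compounds cannot be told apart on these results. The two steps into compound 3 were both flat: no change at the digits printed from compound 1 to compound 3 (within the scatter), and a 1.1-fold higher number from compound 2 to compound 3 (0.04 log units; within the scatter).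

Compound 4, `COc1cc(/C=N/c2c(C)n(C)n(-c3ccccc3)c2=O)ccc1O`, differs from compound 3 by hydroxy in place of hydrogen on an aromatic carbon. Within the data shown here, neither measured step involves a hydroxy group, so no direct precedent exists; what the data show is that two changes on the aromatic ring bearing the carbon with a double bond to nitrogen left this assay unchanged, and that all three numbers sit at the same very weak level.

On that basis no step beyond the scatter is expected: no change at the digits printed from compound 3 to compound 4 (within the scatter). Compound 4 is therefore estimated at 933000000 nM, with a range from 400000000 nM to 2000000000 nM.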

Compound 4, half-maximal inhibitory concentration: 468000000 nM
Estimate against measurement, compound 4: 2.0-fold (0.30 log units) above; measured number inside the range.
By their numbers in this assay, from the lowest: compounds 4, 2, 1 and 3 (each within the scatter of the next).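

In this assay, hydroxy in place of hydrogen on an aromatic carbon, ortho to a methoxy group and para to a large group, gives a 2.0-fold lower number from compound 3 to compound 4 (0.30 log units; within the scatter) and so stays inside the usual scatter. This is the only step shown that brings a hydrogen-bond donor onto this ring, and it shows that this position accepts a hydroxy group with no readable change, leaving all four compounds at the same very weak level. Nothing measured here bears on the reason for this result.

As far as these compounds go, it remains open whether an amine or a carboxylic acid at this position would give a step beyond the scatter. From the compounds shown here alone, it is also open whether a longer chain in place of the methoxy group would do so with the hydroxy group present.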